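From a nitrophenyl to a chlorophenyl on the triazole nitrogen

The compounds below may be only part of what the source reports. "The series", "measured", "known", "first", "only" and "open" are said of these compounds alone.

Of the compounds shown here, two built on the same core have been tested so far. Compound 1 `COc1ccc(-n2cc(COc3ccc(/C=C/C(C)=O)cc3OC)nn2)cc1` is the stronger of the pair: in a functional assay on PC-3 cells (Homo sapiens) for antiproliferative activity, read by MTT assay, with a stated time of 48 h (on this read-out lower numbers stand for stronger inhibition and higher numbers for weaker inhibition), compound 1 gives 2010 nM. Compound 2 `COc1cc(/C=C/C(C)=O)ccc1OCc1cn(-c2ccc([N+](=O)[O-])cc2)nn1` gives 46700 nM in this assay, the higher of the two numbers, and the measured step of a 23-fold higher number from compound 1 to compound 2 (1.37 log units; beyond the scatter) places it well beyond the scatter on the weaker side.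

Compound 3 `COc1cc(/C=C/C(C)=O)ccc1OCc1cn(-c2ccccc2Cl)nn1` has not yet been measured. It differs from compound 2 by 2-chlorophenyl in place of 4-nitrophenyl on an aromatic nitrogen. Among the measured compounds shown here, no measured step covers this exact exchange; the only step that bears on it is the one in which a nitro group entered at the same aromatic nitrogen substituent, a 23-fold higher number from compound 1 to compound 2 (1.37 log units; beyond the scatter), which was large. On these data alone, since compound 3 loses that nitro group, the number is expected to fall back toward the region of compound 1, though the chlorophenyl itself is untested, so the size is uncertain.

Compound 3 is therefore estimated to give 6000 nM in this assay, within a range of 1500 nM to 30000 nM. This estimate means an expected step of a 7.8-fold lower number from compound 2 to compound 3 (0.89 log units; beyond the scatter).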

Compound 3, half-maximal inhibitory concentration: 48000 nM
Compound 3: middle estimate off by 8.0-fold (0.90 log units), on the low side; measured number above the stated range.
By their numbers in this assay, from the lowest: compound 1; then compounds 2 and 3 (each within the scatter of the next).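

In this assay the exchange on the aromatic nitrogen gives a 1.0-fold higher number from compound 2 to compound 3 (0.01 log units; within the scatter) and so shows that the high number of compound 2 does not depend on the nitro group alone, since the 2-chlorophenyl group, which carries no nitro, gives a number within the scatter of it. The other comparison gives a 24-fold higher number from compound 1 to compound 3 (1.38 log units; beyond the scatter) and is about as large as the step to the 4-nitrophenyl group, so the 4-methoxyphenyl group of compound 1 now stands apart from two different replacements on this nitrogen, and among these three compounds only it gives the lower number. No evidence is available on why these exchanges behave this way.

What the compounds shown leave open is whether the 4-methoxyphenyl group is special or whether the other two groups are each unfavourable in their own way, as a plain phenyl or an aminophenyl on the same nitrogen could help to show. The 2-chlorophenyl and 4-nitrophenyl groups also differ in both the substituent and where it sits on the ring, so these compounds cannot separate the two.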